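Trading phenyl for methoxy on an aromatic carbon

This account rests on a few compounds, and the source may have more. Where it says the series, first, only, none or still open, it means among the compounds named here.

Compound 2 `CNC(=O)[C@@]12C[C@@H]1[C@@H](n1cnc3c(NC)nc(C#Cc4ccc(-c5ccccc5)cc4)nc31)[C@H](O)[C@@H]2O` is one of three compounds whose numbers are known. In an assay on CHO cells for displacement of a labelled ligand from adenosine receptor A1 (Homo sapiens), read by scintillation counting, with a stated time of 60 min, tested at 10 uM (on this read-out lower numbers stand for less inhibition and higher numbers for more inhibition at the one concentration tested (going by the name of the read-out)), compound 2 gives 18%. Compound 1 `CNC(=O)[C@@]12C[C@@H]1[C@@H](n1cnc3c(NC)nc(C#Cc4ccccc4)nc31)[C@H](O)[C@@H]2O` gives 18% in this assay, and compound 3 `CNC(=O)[C@@]12C[C@@H]1[C@@H](n1cnc3c(NC)nc(C#Cc4ccccc4OC)nc31)[C@H](O)[C@@H]2O` gives 12%. Compound 2 thus stands level with compound 1 at the digits shown, the two together the highest of the three numbers, and all three lie within the scatter of one another.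

The step to compound 4 `CNC(=O)[C@@]12C[C@@H]1[C@@H](n1cnc3c(NC)nc(C#Cc4ccc(OC)cc4)nc31)[C@H](O)[C@@H]2O` carries the change (methoxy in place of phenyl on an aromatic carbon). Among the measured compounds shown here, three measured steps bear on it: no change at the digits printed from compound 1 to compound 2 (within the scatter), a number 6 percentage points lower from compound 1 to compound 3 (within the scatter) and a number 6 percentage points lower from compound 2 to compound 3 (within the scatter). Each of these, whether a phenyl or a methoxy enters on an aromatic carbon, or a 2-methoxyphenyl stands in place of a 4-phenylphenyl on the triple-bonded carbon, leaves the read-out where it was within the scatter. No step beyond the scatter is therefore expected in this assay for compound 4. Compound 4 is estimated at 15%, expected to fall between 5% and 27%. The expected step is thus a number 3 percentage points lower from compound 2 to compound 4 (within the scatter).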

Compound 4, a percentage reported as inhibition, at one concentration (the size of the read-out at that concentration, not a potency): 10%
Estimate against measurement, compound 4: 5 percentage points above; measured number inside the range.
By their numbers in this assay, from the lowest: compounds 4, 3, 1 and 2 (each within the scatter of the next).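

In this assay the aromatic carbon para to a large group can now be compared across three occupants: hydrogen in compound 1, phenyl in compound 2 and methoxy in compound 4. Methoxy in place of phenyl there gives a number 8 percentage points lower from compound 2 to compound 4 (within the scatter) and methoxy in place of hydrogen gives a number 8 percentage points lower from compound 1 to compound 4 (within the scatter) so on this read-out none of the three occupants is separated from the others. The methoxy group's place on the ring does not separate the compounds either, since 4-methoxyphenyl in place of 2-methoxyphenyl gives a number 2 percentage points lower from compound 3 to compound 4 (within the scatter) and the read-out stays within the scatter.

From the compounds shown here alone, whether an amine, a carboxylic acid or a longer chain at this carbon would carry the read-out beyond the scatter remains open. No supporting evidence is available to explain these numbers.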